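Moving a trifluoromethyl benzyl variant within a sulfonyl guanidine series

The source may hold more compounds than are shown below. What is called first, only, known or untested is meant among the compounds shown, and "the series" means these compounds.

Of the compounds shown here, three sharing one core have been measured in a functional assay on HCT-116 cells (Homo sapiens) for cytotoxicity, read by MTT assay, with a stated time of 72 h; a lower number here means a stronger inhibitor, a higher number a weaker inhibitor. Compound 1 `Cc1cc(-c2ccccc2)n(/C(N)=N/S(=O)(=O)c2cc(C)c(Cl)cc2SCc2cccc3ccccc23)n1` gives 7000 nM, compound 2 `Cc1cc(-c2ccccc2)n(/C(N)=N/S(=O)(=O)c2cc(C)c(Cl)cc2SCc2cccc(C(F)(F)F)c2)n1` gives 19000 nM, and compound 3 `Cc1cc(-c2ccccc2)n(/C(N)=N/S(=O)(=O)c2cc(C)c(Cl)cc2SCc2cccc(Cl)c2)n1` gives 18000 nM. Compound 3 thus stands second highest of the three numbers: it sits within the scatter of compound 2, while a 2.6-fold higher number from compound 1 to compound 3 (0.41 log units; beyond the scatter) places it clearly apart from compound 1.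

Compound 4 `Cc1cc(-c2ccccc2)n(/C(N)=N/S(=O)(=O)c2cc(C)c(Cl)cc2SCc2ccccc2C(F)(F)F)n1` differs from compound 3 by 2-(trifluoromethyl)phenyl in place of 3-chlorophenyl on a saturated chain carbon bound to a sulfur. Of the measured steps, only a 1.1-fold lower number from compound 2 to compound 3 (0.02 log units; within the scatter) bears on part of this change, the exchange of chloro for trifluoromethyl, and it was within the scatter. For the measured compounds named here, no measured pair informs the shift of the substituent to the position it takes in compound 4, so that part is unknown. On that basis compound 4 is expected to show a 1.1-fold lower number from compound 3 to compound 4 (0.02 log units; within the scatter), a step not beyond the scatter. The estimate for compound 4 in this assay is 17000 nM, with a range from 7000 nM to 40000 nM.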

Compound 4, half-maximal inhibitory concentration: 25000 nM
Compound 4: middle estimate off by 1.5-fold (0.17 log units), on the low side; the range from low to high includes it.
By their numbers in this assay, from the lowest: compound 1; then compounds 3, 2 and 4 (each within the scatter of the next).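

In this assay, for the compounds shown here, placing the trifluoromethyl group as in 2-(trifluoromethyl)phenyl gives a 1.3-fold higher number from compound 2 to compound 4 (0.12 log units; within the scatter), and replacing 3-chlorophenyl with that same group gives a 1.4-fold higher number from compound 3 to compound 4 (0.14 log units; within the scatter), so the first measured change of substituent position at this site leaves the number within the scatter. Naphthalen-1-yl remains apart from all three substituted phenyl groups, now with a 3.6-fold higher number from compound 1 to compound 4 (0.55 log units; beyond the scatter). No measurement shown offers an explanation for either finding.

As far as these compounds go, it remains open whether a phenyl group without a substituent, or one carrying a methoxy group or an amine, would fall with these three or with compound 1 on the saturated chain carbon bound to a sulfur. From the compounds shown here alone, since the rest of the core stays the same throughout, it is also open whether these steps would hold on a different core.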